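This account rests on a few compounds, and the source may have more. Where it says the series, first, only, none or still open, it means among the compounds named here.

Going by the values given here, compound 1 `O=C1C(Nc2ccc(-c3ccccc3)cc2)=CC(=O)c2ncncc21` holds the only plain numeric value here: in a functional assay on BXPC-3 cells (Homo sapiens) for cytotoxicity, read by MTT assay, with a stated time of 72 h (a higher number here means a weaker inhibitor, a lower number a stronger inhibitor), compound 1 gives 500 nM. Compound 2 `O=C1C(Nc2cccc(B(O)O)c2)=CC(=O)c2ncncc21` gives only a limit of this assay, > 10000 nM. Compound 3 `NC(=O)c1ccc(NC2=CC(=O)c3ncncc3C2=O)cc1` differs from compound 1 by carbamoyl in place of phenyl on an aromatic carbon. Among the compounds with values here, no measured pair shares this change, so the step can only be estimated. Within the data shown here, the sole comparison, compound 2 with its value of > 10000 nM, is a limit and marks a loss for a different change on that ring (the limit of > 10000 nM in this assay, at which 1 of the 2 values shown sits). The expected step of a 6.0-fold higher number from compound 1 to compound 3 (0.78 log units; beyond the scatter) points toward weaker inhibition. Compound 3 is estimated at 3000 nM, within 800 nM to 12000 nM.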

Compound 3, half-maximal inhibitory concentration: > 10000 nM
Compound 3 was reported as a limit (the forecaster's own chance of this, stated with the estimate: 30%); middle value at least 3.3-fold (0.52 log units) from the limit.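

On this aromatic carbon, para to a large group, carbamoyl in place of phenyl brings an at least 20-fold higher number from compound 1 to compound 3 (1.30 log units; beyond the scatter), a large loss in this assay. On these data alone, the value of compound 3 is a limit, so the true size of this step stays unknown. Compound 1 alone now keeps a plain number: the limit of > 10000 nM in this assay, at which 2 of the 3 values shown sit.

Carbamoyl differs from phenyl in its heavy atoms, its lack of a ring and its hydrogen-bond donor and acceptor all at once, so which of these matters stays open. A pyridyl ring or a methyl group on this carbon could help separate them.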